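The compounds below may be only part of what the source reports. "The series", "measured", "known", "first", "only" and "open" are said of these compounds alone.

Working notes: in an ADME assay on microsomes from liver (Mus musculus) for metabolic stability, read by LC-MS, using NADPH, tested at 4.6 uM (on this read-out higher numbers stand for a longer-lived compound and lower numbers for a shorter-lived compound), compound 1 (`O=C(NCCCCc1ccccc1)n1cc(-c2ccc(F)cc2)oc1=O`) gives 1 h, the only actual number so far. Compound 2 (`CN1CCC(c2cc(-c3cn(C(=O)NCCCCc4ccccc4)c(=O)o3)ccc2F)CC1`) gives > 1 h, which is a limit. Compound 3 (`CN1CCC(c2cc(F)ccc2-c2cn(C(=O)NCCCCc3ccccc3)c(=O)o2)CC1`) differs from compound 1 by 1-methylpiperidin-4-yl in place of hydrogen on an aromatic carbon, with the new group ortho to a large group and meta to a fluoro group. Going by the values given here, the one bearing step places the same group on another aromatic carbon: a number no lower from compound 1 to compound 2 (the limit leaves the size open). As far as these compounds go, that step rests on (the limit of > 1 h in this assay, at which 1 of the 2 values shown sits), so its size stays open. In this assay, the expected step of a 1.2-fold higher number from compound 1 to compound 3 (0.08 log units; within the scatter) stays within the scatter, with no clear direction. For compound 3 the estimated half-life is 1.2 h, with an expected range of 0.6 h to 2.5 h.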

Compound 3, half-life: > 1 h
Compound 3: a limit, no number (the forecaster's own chance of this, stated with the estimate: 55%); the middle value lies beyond the limit too.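

Compound 3 gives > 1 h in this assay, which is a limit and not a number. So with 1-methylpiperidin-4-yl ortho to a large group and meta to a fluoro group, the read-out again stands at a limit, as it does for compound 2 with the same group on another aromatic carbon. The step is a number no lower from compound 1 to compound 3 (the limit leaves the size open) and its size cannot be read: the limit of > 1 h in this assay, at which 2 of the 3 values shown sit.

As far as these compounds go, how far the half-life moves with 1-methylpiperidin-4-yl at either carbon stays open, as does any order between compound 2 and compound 3. Also open, from the compounds shown here alone, is what a carboxylic acid or a primary amine on this aromatic carbon would give.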